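This account rests on a few compounds, and the source may have more. Where it says the series, first, only, none or still open, it means among the compounds named here.

Measured compounds, cytotoxicity:

Compound 1, `COc1ccc(C(=O)Nc2cc3nc(C4CCCCC4)[nH]c3cc2N(C)C)cc1`: > 100 ug/mL
Compound 2, `CN(C)c1cc2[nH]c(C3CCCCC3)nc2cc1NC(=O)c1ccco1`: > 100 ug/mL
Compound 3, `Cc1ccc(C(=O)Nc2cc3nc(C4CCCCC4)[nH]c3cc2N(C)C)cc1`: > 100 ug/mL

In an ADME assay on Vero cells (Chlorocebus sabaeus) for cytotoxicity, read by resazurin assay, with a stated time of 3 days (a lower number here means a stronger inhibitor, a higher number a weaker inhibitor), compound 1 gives > 100 ug/mL, which is a limit of the assay rather than a number. In this assay compound 2 likewise gives > 100 ug/mL, again a limit. Compound 3 gives > 100 ug/mL in this assay, also a limit. Among the measured compounds shown here, compound 3 therefore stands at the same limit as the two others; the limit of > 100 ug/mL in this assay, at which 3 of the 3 values shown sit, records that every value so far sits there.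

Compound 4, `CCCOCC(=O)Nc1cc2nc(C3CCCCC3)[nH]c2cc1N(C)C`, has yet to be measured in this assay. It differs from compound 3 as follows: propoxymethyl in place of 4-methylphenyl on a carbonyl carbon. The measured steps that touch the group on the carbonyl carbon are a step that the two limits leave unreadable from compound 1 to compound 3 and a step that the two limits leave unreadable from compound 2 to compound 3, and the third, a step that the two limits leave unreadable from compound 1 to compound 2, is equally unreadable, since all three values are limits. No size can be drawn from them. The expectation for compound 4 is that the step of a number no higher from compound 3 to compound 4 (the limit leaves the size open) adds nothing beyond the scatter, and that compound 4 is estimated at 100 ug/mL, within 50 ug/mL to 200 ug/mL, most likely reported again only as a limit.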

Compound 4, half-maximal inhibitory concentration: < 50 ug/mL
Compound 4: only a limit was reported; the forecaster's own chance of this, stated with the estimate: 85%; at least 2.0-fold (0.30 log units) between middle value and limit.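

Changing the group on the carbonyl carbon can move the read-out off the upper limit in this assay, and compound 4 gives < 50 ug/mL, which is a limit of the assay and not a number. Propoxymethyl gives an at least 2.0-fold lower number from compound 3 to compound 4 (0.30 log units; that floor lies within the scatter), an at least 2.0-fold lower number from compound 2 to compound 4 (0.30 log units; that floor lies within the scatter) and an at least 2.0-fold lower number from compound 1 to compound 4 (0.30 log units; that floor lies within the scatter), and these floors are all that can be read of the size. The steps among compound 1, compound 2 and compound 3 cannot be read, and these compounds, each with a ring on the carbonyl carbon, share one limit that compound 4, with no ring there, does not reach: the limit of > 100 ug/mL in this assay, at which 3 of the 4 values shown sit.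

From the compounds shown here alone, whether the difference goes with the loss of the ring or with the ether oxygen stays open, and a plain pentyl chain on the carbonyl carbon would separate the two. Going by these compounds, the real value of compound 4 also stays open, as does the reading for a chain ending in an amine.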